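From Pyrrolidin-1-yl to 2,3-Dihydro-1H-indol-1-yl on Compound 2

A few compounds are considered here, and "the series" means these few. Any claim that something is new, unique, unknown or untested is made for them only; others in the source may bear on it.

Measured compounds:
Compound 1, `c1cc(N2CCCCC2)nc(Nc2ccc(Oc3ncnc4sccc34)cc2)n1`, gives 66.3% in a functional assay on HCT-116 cells (Homo sapiens) for inhibition, read by MTT assay, with a stated time of 72 h, tested at 20 uM; a lower number here means less inhibition, a higher number more inhibition at the concentration tested (going by the name of the read-out).
Compound 2, `CN(c1ccc(Oc2ncnc3ccsc23)cc1)c1nccc(N2CCCC2)n1`, gives 63.6%.
Compound 3, `CNC(=O)c1cc(Oc2ccc(Nc3nccc(N4CCCCC4)n3)cc2)ccn1`, gives 69.8%.

Compound 2 sits at the lower end of these three numbers, yet its gaps to compound 1 and to compound 3 both lie within the usual scatter, so the three compounds read as alike in this assay.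

Compound 4, `CN(c1ccc(Oc2ncnc3ccsc23)cc1)c1nccc(N2CCc3ccccc32)n1`, has not been measured. It differs from compound 2 in one place: 2,3-dihydro-1H-indol-1-yl in place of pyrrolidin-1-yl on an aromatic carbon. The pyrrolidin-1-yl of compound 2 is thus replaced by the larger 2,3-dihydro-1H-indol-1-yl, which adds a six-membered aromatic ring of carbon only fused to the five-membered ring.

Among the compounds with values here, only one measured step exists, a number 3.5 percentage points higher from compound 1 to compound 3 (within the scatter), and it concerns the group on the oxygen, not the ring amine. Within the data shown here, no measured step touches the position that changes here, and compound 1 and compound 2, which differ at that amine among other places, give numbers within the scatter of each other.

With nothing pointing either way, no step beyond the scatter is expected, and the step of a number 0.4 percentage points higher from compound 2 to compound 4 (within the scatter) is the estimate. Compound 4 is therefore expected to give about 64%, between 50% and 78%.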

Compound 4, a percentage reported as inhibition, at one concentration (the size of the read-out at that concentration, not a potency): 57.8%
Compound 4: middle estimate off by 6.2 percentage points, on the high side; low and high end bracket the measured number.
By their numbers in this assay, from the lowest: compounds 4, 2, 1 and 3 (each within the scatter of the next, the first and the last beyond it).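

In this assay, within the data shown here, putting 2,3-dihydro-1H-indol-1-yl in place of pyrrolidin-1-yl gives a number 5.8 percentage points lower from compound 2 to compound 4 (within the scatter) and is the first step read directly at this place: an aromatic carbon of the six-membered aromatic ring with 2 nitrogen, next to the ring nitrogen. Adding a six-membered aromatic ring of carbon only to the group at this place therefore leaves compound 4 indistinguishable from compound 2 in this single-concentration read-out, so the added ring brings no change that can be told apart from ordinary repeat variation. No supporting measurement bears on why this step has the size it does.

From the compounds shown here alone, it remains open whether a morpholine ring, an open-chain dimethylamino group or a piperazine ring carrying a terminal amine would also stay within the scatter at this carbon. Also open, going by these compounds, is whether the same swap would give a step of similar size on the core of compound 1 or compound 3, and whether compound 2 and compound 4 would remain alike across a range of concentrations rather than at one.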